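Moving the fluorine on the sulfonyl aryl ring

This account rests on a few compounds, and the source may have more. Where it says the series, first, only, none or still open, it means among the compounds named here.

Values from an assay on MDA-MB-231 cells for binding affinity to C-X-C chemokine receptor type 4 (Homo sapiens), read by fluorescence and microscopy, with stated times of 10 min and 30 min; a lower number here means that less compound is needed, a higher number that more compound is needed for the effect:
compound 1 `O=C(NCc1ccc(CNS(=O)(=O)c2cccc(C(F)(F)F)c2)cc1)c1ccc(F)cc1`: 100 nM
compound 2 `O=C(NCc1ccc(CNS(=O)(=O)c2cccc(Cl)c2)cc1)c1ccc(F)cc1`: 1 nM
compound 3 `O=C(NCc1ccc(CNS(=O)(=O)c2ccccc2F)cc1)c1ccc(F)cc1`: 10 nM

Compound 3 stands second highest of the three numbers: compound 1 is a 10-fold lower number from compound 1 to compound 3 (1.00 log units; beyond the scatter) reversed in direction, while compound 2 sits a 10-fold higher number from compound 2 to compound 3 (1.00 log units; beyond the scatter) below it. Compound 4 `O=C(NCc1ccc(CNS(=O)(=O)c2ccc(F)cc2)cc1)c1ccc(F)cc1` keeps the same atoms, joined differently: 4-fluorophenyl in place of 2-fluorophenyl on a sulfonyl sulfur. Within the data shown here, no measured step moves a fluorine around this ring; the steps that exist, a 100-fold lower number from compound 1 to compound 2 (2.00 log units; beyond the scatter) and a 10-fold higher number from compound 2 to compound 3 (1.00 log units; beyond the scatter), show that changes on this ring can shift this assay strongly in either direction. The direction for compound 4 cannot be read from them, so the expected step of no change at the digits printed from compound 3 to compound 4 (within the scatter) is about none, with wide uncertainty. Compound 4 is therefore estimated at 10 nM, within 2 nM to 60 nM.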

Compound 4, effective concentration (reported as EC, without a stated level of effect): 1 nM
The estimate for compound 4 lay 10-fold (1.00 log units) above the measured number; measured number below the stated range.
By their numbers in this assay, from the lowest: compounds 2 and 4 (each within the scatter of the next); then compound 3; then compound 1.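

Moving the fluorine alone, with the atoms unchanged, matters in this assay: 4-fluorophenyl in place of 2-fluorophenyl on the sulfonyl sulfur gives a 10-fold lower number from compound 3 to compound 4 (1.00 log units; beyond the scatter). So the place of a substituent on this ring counts, not just its identity, and the other steps read no change at the digits printed from compound 2 to compound 4 (within the scatter) and a 100-fold lower number from compound 1 to compound 4 (2.00 log units; beyond the scatter). Nothing available explains why the place of the fluorine matters.

Still open, going by these compounds, is whether a methoxy group or an amine in place of this fluorine would keep the number as low.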